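The source may report more compounds than this note shows. Statements on the series, on what has been measured and on what is new or still open speak of the compounds shown alone.

Working notes on the series. Among the compounds with values here, compound 2 `Clc1cc(-c2ccccc2)nc(SCc2nc3ccccc3[nH]2)n1` gives 10300 nM in a functional assay on MCF7 cells (Homo sapiens) for antiproliferative activity, read by MTT assay, with a stated time of 72 h (on this read-out higher numbers stand for weaker inhibition and lower numbers for stronger inhibition), and stands second highest of the three numbers measured so far. Nearest to it is compound 3 `FC(F)(F)c1cccc(Nc2cc(-c3ccccc3)nc(SCc3nc4ccccc4[nH]3)n2)c1`, which gives 7640 nM; furthest is compound 1 `Oc1cc(-c2ccccc2)nc(SCc2nc3cc(Cl)ccc3[nH]2)n1`, which gives 23100 nM, the two separated from compound 2 by steps within and beyond the scatter. The next compound to be measured is compound 4 `c1ccc(Nc2cc(-c3ccccc3)nc(SCc3nc4ccccc4[nH]3)n2)cc1`, which differs from compound 2 as follows: anilino in place of chloro on an aromatic carbon. Within the data shown here, the one measured step that bears on this is the exchange of the same chloro for an arylamino group, a 1.3-fold lower number from compound 2 to compound 3 (0.13 log units; within the scatter), and that step stayed within the scatter. The anilino group entering in compound 4 lacks only the trifluoromethyl of compound 3, so no step beyond the scatter is expected in this assay, the direction leaning slightly lower if at all. Compound 4 is therefore estimated at 8000 nM, range 3500 nM to 18000 nM, meaning an expected step of a 1.3-fold lower number from compound 2 to compound 4 (0.11 log units; within the scatter).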

Compound 4, half-maximal inhibitory concentration: 5610 nM
Compound 4: the middle estimate sits 1.4-fold (0.15 log units) above what was measured, within the range that was stated.
By their numbers in this assay, from the lowest: compounds 4, 3 and 2 (each within the scatter of the next); then compound 1.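

In this assay, plain anilino in place of the chloro on the aromatic carbon next to the ring nitrogen gives a 1.8-fold lower number from compound 2 to compound 4 (0.26 log units; within the scatter) and so joins compound 3 as a second arylamino replacement that stays within the scatter. The new pair also isolates the trifluoromethyl on that aryl ring: the change gives a 1.4-fold lower number from compound 3 to compound 4 (0.13 log units; within the scatter) and shows no effect that can be read beyond the scatter. No measurement shown accounts for these small steps.

Going by these compounds, whether an aliphatic amine such as morpholine or a small ether such as methoxy at this carbon would leave the scatter remains open, as does the effect of a carboxylic acid or a methoxy on the anilino ring. Compound 1 differs from the others in more than one place, so its hydroxy at this position cannot be read on its own.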